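Lengthening a Hydroxamic Acid Chain on a Lactone Core

The compounds below may be only part of what the source reports. "The series", "measured", "known", "first", "only" and "open" are said of these compounds alone.

Compound 1 `CC(C)CCc1c(OCCCCCCCC(=O)NO)ccc(CCC(=O)NO)c1O` and compound 2 `CC(C)CCc1c(OCCCCC(=O)NO)ccc(CCC(=O)NO)c1O` share a core and differ in one place: 3-(hydroxycarbamoyl)propyl in place of hydroxycarbamoyl on a saturated chain carbon, four bonds along the chain from an oxygen on an aromatic ring. In a functional assay on Hep 3B2 cells (Homo sapiens) for antiproliferative activity, read by sulforhodamine B assay, with a stated time of 48 h (a lower number here means a stronger inhibitor of growth, a higher number a weaker inhibitor of growth), compound 2 gives 14100 nM, while compound 1 gives 1270 nM, so the longer chain brought an 11-fold lower number from compound 2 to compound 1 (1.05 log units; beyond the scatter). Compound 3 `CC(C)CCc1c(OCCCCC(=O)NO)ccc2c1OC(=O)CC2` carries a different core; how it differs from the core of compound 2 is not broken down here. For compound 3 this assay gives only a limit, > 30000 nM, at the limit of > 30000 nM in this assay, at which 1 of the 3 values shown sits. Compound 4 `CC(C)CCc1c(OCCCCCCCC(=O)NO)ccc2c1OC(=O)CC2` has not been measured; it stands to compound 3 as compound 1 stands to compound 2, with the same change: 3-(hydroxycarbamoyl)propyl in place of hydroxycarbamoyl on a saturated chain carbon, four bonds along the chain from an oxygen on an aromatic ring. Going by the values given here, the one measured example of this change, from compound 2 to compound 1, was large, and on that alone compound 4 is expected to sit at roughly an at least 5.0-fold lower number from compound 3 to compound 4 (0.69 log units; beyond the scatter) from compound 3 in this assay. Because compound 3 rests at a limit, > 30000 nM, the starting point is itself uncertain, and the estimate for compound 4 in this assay is 6000 nM, expected to fall between 1500 nM and 30000 nM.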

Compound 4, concentration for 50% growth inhibition: > 30000 nM
Compound 4 gave a limit, no number; the forecaster's own chance of this, stated with the estimate: 25%; middle value at least 5.0-fold (0.69 log units) away from the limit.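

In this assay compound 4 gives > 30000 nM as a limit, not a number. Going by these compounds alone, no step from compound 3 to compound 4 can be read, because both stand at the same limit: the limit of > 30000 nM in this assay, at which 2 of the 4 values shown sit. Going by these compounds, whether 3-(hydroxycarbamoyl)propyl in place of hydroxycarbamoyl changes growth inhibition on the core of compound 3 at all remains open.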